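The source may report more compounds than this note shows. Statements on the series, on what has been measured and on what is new or still open speak of the compounds shown alone.

Measured so far in a functional assay on Molt4/C8 cells (Homo sapiens) for cytotoxicity; on this read-out lower numbers stand for stronger inhibition and higher numbers for weaker inhibition:
- compound 1 `O=C(/C=C/C(=O)N1C/C(=C\c2ccccc2)C(=O)/C(=C/c2ccccc2)C1)Nc1ccc([N+](=O)[O-])cc1`: compound 1 gives 31000 nM
- compound 2 `CC(=O)c1ccc(NC(=O)/C=C/C(=O)N2C/C(=C\c3ccccc3)C(=O)/C(=C/c3ccccc3)C2)cc1`: compound 2 gives 1400 nM
- compound 3 `Cc1ccc(NC(=O)/C=C/C(=O)N2C/C(=C\c3ccccc3)C(=O)/C(=C/c3ccccc3)C2)cc1`: compound 3 gives 660 nM

Compound 3 stands at the lowest number of the three. The step of a 2.1-fold lower number from compound 2 to compound 3 (0.33 log units; beyond the scatter) and the step of a 47-fold lower number from compound 1 to compound 3 (1.67 log units; beyond the scatter) are both beyond the scatter, so compound 3 is the most potent of the measured set in this assay, and the group on the aryl amide is the only place where the three differ.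

Compound 4 `O=C(/C=C/C(=O)N1C/C(=C\c2ccccc2)C(=O)/C(=C/c2ccccc2)C1)Nc1ccc(Cl)cc1` differs from compound 3 in one place: chloro in place of methyl on an aromatic carbon. Among the compounds with values here, no measured step covers chloro at this position. Within the data shown here, the steps that bear on it are those at the same aromatic carbon: a 47-fold lower number from compound 1 to compound 3 (1.67 log units; beyond the scatter), a 2.1-fold lower number from compound 2 to compound 3 (0.33 log units; beyond the scatter) and a 22-fold lower number from compound 1 to compound 2 (1.35 log units; beyond the scatter). Both measured exchanges of the methyl for another group gave a higher number, one large and one modest, which shows that this position moves this assay. Since chloro is not among the groups measured, a small step towards a higher number is expected, within or just beyond the scatter, rather than a large one.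

The estimate for compound 4 in this assay is 900 nM, with a range from 350 nM to 2500 nM, which is the expected step of a 1.4-fold higher number from compound 3 to compound 4 (0.13 log units; within the scatter).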

Compound 4, half-maximal inhibitory concentration: 1800 nM
Beside the measured number, compound 4's estimate is 2.0-fold (0.30 log units) below it, within the range that was stated.
By their numbers in this assay, from the lowest: compound 3; then compounds 2 and 4 (each within the scatter of the next); then compound 1.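

In this assay, compound 3 keeps its place as the most potent of the four, and the exchange of methyl for chloro also gives a higher number (a 2.7-fold higher number from compound 3 to compound 4 (0.44 log units; beyond the scatter)). This step is beyond the scatter even though the two groups have the same counts of heavy atoms, hydrogen-bond donors and hydrogen-bond acceptors, so those counts alone do not settle the read-out at this position. Chloro and acetyl cannot be told apart here (a 1.3-fold higher number from compound 2 to compound 4 (0.11 log units; within the scatter)), whereas chloro stands far from nitro (a 17-fold lower number from compound 1 to compound 4 (1.24 log units; beyond the scatter)), which leaves compound 1 alone at the weak end of the set, and nothing on hand accounts for any of these differences.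

Going by these compounds, it remains open whether an amine, a methoxy group or a longer chain such as ethyl on this aromatic carbon would give a number lower than that of compound 3 or would fall among the higher ones. On these data alone, all four compounds carry their variable group at this one place, so the effect of methyl or chloro elsewhere on the aromatic ring, or of changes to the shared core, also remains open.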